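Adding a Methyl Group to Compound 2

The source may hold more compounds than are shown below. What is called first, only, known or untested is meant among the compounds shown, and "the series" means these compounds.

Measured so far in an ADME assay on PANC-1 cells (Homo sapiens) for inhibition, read by MTT assay, with a stated time of 90 h; on this read-out higher numbers stand for weaker inhibition of growth and lower numbers for stronger inhibition of growth:
Compound 1 `O=C(CC(=O)c1ccccc1O)c1cc2ccccc2s1` gives 7.77 ug/mL.
Compound 2 `O=C(CC(=O)c1cc(Cl)ccc1O)c1cc2ccccc2s1` gives 8.44 ug/mL.
Compound 3 `O=C(CC(=O)c1cc(Br)ccc1O)c1cc2ccccc2s1` gives 18.3 ug/mL.

Compound 2 stands second highest of these three numbers, close to compound 1 and separated from compound 3 by a modest gap. Compound 4 `Cc1cc(O)c(C(=O)CC(=O)c2cc3ccccc3s2)cc1Cl` differs from compound 2 by methyl in place of hydrogen on an aromatic carbon, at the aromatic carbon ortho to the chloro group and meta to the hydroxy group. Going by the values given here, the steps that bear on this ring are a 1.1-fold higher number from compound 1 to compound 2 (0.04 log units; within the scatter), a 2.4-fold higher number from compound 1 to compound 3 (0.37 log units; beyond the scatter) and a 2.2-fold higher number from compound 2 to compound 3 (0.34 log units; beyond the scatter): a halogen on the ring bearing the hydroxy group left the number nearly unchanged or raised it modestly, and there is no precedent for a methyl group. A small step toward a higher number, or none beyond the scatter, is therefore expected. Compound 4 is estimated at 10.5 ug/mL, within 5 ug/mL to 22 ug/mL, meaning an expected 1.2-fold higher number from compound 2 to compound 4 (0.09 log units; within the scatter).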

Compound 4, concentration for 50% growth inhibition: 20.4 ug/mL
The estimate for compound 4 lay 1.9-fold (0.29 log units) below the measured number; the range from low to high includes it.
By their numbers in this assay, from the lowest: compounds 1 and 2 (each within the scatter of the next); then compounds 3 and 4 (each within the scatter of the next).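

In this assay, methyl in place of hydrogen on the aromatic carbon ortho to the chloro group gives a 2.4-fold higher number from compound 2 to compound 4 (0.38 log units; beyond the scatter) and so moves the number toward weaker inhibition of growth. The earlier compounds shown here showed changes only at the halogen carbon; this result shows that the number also responds to a single added carbon at this second ring position. No measurement available here accounts for the step.

As far as these compounds go, whether the step depends on the chloro group remains open. So does how an ethyl group, a methoxy group or an amine would read at this carbon.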